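A few compounds are considered here, and "the series" means these few. Any claim that something is new, unique, unknown or untested is made for them only; others in the source may bear on it.

Of the compounds shown here, three share one core and have been measured so far. Compound 1 `Cc1cc(NC(=O)Nc2ccc(C(C)(C)C)cc2)c2ccccc2n1` gives 6200 nM in a physicochemical assay for solubility, at pH 7.4; on this read-out lower numbers stand for lower solubility and higher numbers for higher solubility. Compound 2 `Cc1cc(NC(=O)Nc2ccc(Cl)cc2)c2ccccc2n1` gives 1400 nM in this assay, and compound 3 `Cc1cc(NC(=O)Nc2cccc(Cl)c2)c2ccccc2n1` gives 800 nM. Compound 2 and compound 3 differ only in 3-chlorophenyl in place of 4-chlorophenyl on an amide-type nitrogen, and the step of a 1.8-fold lower number from compound 2 to compound 3 (0.24 log units; within the scatter) stays within the scatter, so the two cannot be told apart, while compound 1 lies clearly higher than both. Between compound 2 and compound 1 the change is tert-butyl in place of chloro on an aromatic carbon, and it brought a 4.4-fold higher number from compound 2 to compound 1 (0.65 log units; beyond the scatter).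

Compound 4 `Cc1cc(NC(=O)Nc2cccc(C(C)(C)C)c2)c2ccccc2n1` has not yet been measured. It arises from compound 3 by tert-butyl in place of chloro on an aromatic carbon. This is the same kind of change as that from compound 2 to compound 1, though not the same: in compound 1 the entering group sits para to a large group, in compound 4 meta to it. Compound 4 is expected to show a step of about a 3.8-fold higher number from compound 3 to compound 4 (0.57 log units; beyond the scatter) in this assay, because the same kind of change gave a 4.4-fold higher number from compound 2 to compound 1 (0.65 log units; beyond the scatter). Compound 4 is thus estimated at 3000 nM, with a likely range from 1100 nM to 9000 nM.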

Compound 4, solubility: 34700 nM
Compound 4: middle estimate off by 12-fold (1.06 log units), on the low side, and the stated range ends below it.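

Tert-butyl in place of chloro on an aromatic carbon again gave a higher number in this assay when carried over, now with (a 43-fold higher number from compound 3 to compound 4 (1.64 log units; beyond the scatter)) against the earlier (a 4.4-fold higher number from compound 2 to compound 1 (0.65 log units; beyond the scatter)), so the direction held across both pairs while the size of the step did not. These two pairs show only that the direction repeated here; they do not show that the size of a step can be carried from one setting to another, nor that the place meta to a large group is what set the larger step apart. Nothing shown bears on why the two steps differ in size.

The compounds shown leave open how the same change would behave at other places on the ring. They also leave open whether another group entering in place of chloro, such as an amine, a carboxylic acid or a longer chain, would follow tert-butyl in direction or in size.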